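The source may hold more compounds than are shown below. What is called first, only, known or untested is meant among the compounds shown, and "the series" means these compounds.

Three compounds of one shared core have been run in a functional assay on cells (Pituitary gland cell) for antagonist activity at Gonadotropin-releasing hormone receptor (Rattus norvegicus); on this read-out lower numbers stand for stronger inhibition and higher numbers for weaker inhibition. Compound 1 `O=C(Nc1cc2c(OCCC3CCCCN3)c(-c3ccc(Cl)c(Cl)c3)c(O)nc2cc1Cl)NC1CC1` gives 18 nM. Compound 3 `O=[N+]([O-])c1cc2c(OCCC3CCCCN3)c(-c3cc(C(F)(F)F)cc(C(F)(F)F)c3)c(O)nc2cc1Cl` gives 71 nM. Compound 2 `Cc1ccc(-c2c(O)nc3cc(Cl)c([N+](=O)[O-])cc3c2OCCC2CCCCN2)c(C)c1` gives 400 nM, the highest number of the three, and its gaps to compound 3 and to compound 1 both lie beyond the scatter, so it is the weakest of the measured set in this assay.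

Compound 4 `O=[N+]([O-])c1cc2c(OCCC3CCCCN3)c(-c3cc(Cl)cc(Cl)c3)c(O)nc2cc1Cl` has not yet been measured. It differs from compound 2 in one place: 3,5-dichlorophenyl in place of 2,4-dimethylphenyl on an aromatic carbon. The core, with its nitro group and its 2-(piperidin-2-yl)ethoxy group, is the same as in compound 2 and compound 3. For the measured compounds named here, no pair of measured compounds differs in exactly this way, so the step has to be judged from the whole set. Compound 3, which carries a halogenated aryl group on the same core, gives 71 nM, and compound 1, which carries a dichlorophenyl group, gives 18 nM.

Compound 4 is therefore expected to give a lower number than compound 2, with an estimated step of a 5.0-fold lower number from compound 2 to compound 4 (0.70 log units; beyond the scatter), a move beyond the scatter. The estimate for compound 4 is 80 nM, within a range from 25 nM to 250 nM.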

Compound 4, half-maximal inhibitory concentration: 24 nM
Estimate against measurement, compound 4: 3.3-fold (0.52 log units) above; the whole stated range lies above it.
By their numbers in this assay, from the lowest: compounds 1 and 4 (each within the scatter of the next); then compound 3; then compound 2.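

On the shared core with its nitro group and its 2-(piperidin-2-yl)ethoxy group, the swap of 2,4-dimethylphenyl for 3,5-dichlorophenyl gives in this assay a 17-fold lower number from compound 2 to compound 4 (1.22 log units; beyond the scatter), so the aryl group at this position alone moves the number by a large margin, although both groups have the same count of heavy atoms. On this same core, compound 3 gives 71 nM and compound 4 gives 24 nM, so three aryl groups at this position now have values that can be read side by side. No measurement shown here accounts for the size of this step.

As far as these compounds go, it remains open whether the step follows the exchange of methyl for chlorine or the different placement of the two substituents. On this core, 3,5-dimethylphenyl and 2,4-dichlorophenyl would separate the two.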